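The source may hold more compounds than are shown below. What is called first, only, known or untested is meant among the compounds shown, and "the series" means these compounds.

Compound 2, `C=CCN(CC=C)C(=S)N/N=C(/C)c1ccc(O)cc1`, is the reference point here. In an ADME assay on Vero cells (Chlorocebus sabaeus) for cytotoxicity, read by MTT assay, with a stated time of 72 h (on this read-out lower numbers stand for higher toxicity in this test and higher numbers for lower toxicity in this test), compound 2 gives 216000 nM. Among the measured compounds shown here, only one other compound has been measured alongside it, compound 1, `C=CCN(CC=C)C(=S)N/N=C(/C)c1ccc(F)cc1`, which in this assay gives 214000 nM; the step of a 1.0-fold higher number from compound 1 to compound 2 (0.00 log units; within the scatter) leaves the two compounds level with each other, so compound 2 sits at the same level as its single neighbour rather than apart from it.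

Compound 3, `C=CCN(CC=C)C(=S)N/N=C(/C)c1ccc([N+](=O)[O-])cc1`, has not yet been measured. It differs from compound 2 in one place: nitro in place of hydroxy on an aromatic carbon. For the measured compounds named here, the only measured step that bears on this change is the one at the same position, a 1.0-fold higher number from compound 1 to compound 2 (0.00 log units; within the scatter), which did not move the read-out beyond the scatter. Going by the values given here, with one swap at this position having produced no step, there is no basis for expecting that a second swap there will do otherwise, and the step expected from the change is estimated as a 1.0-fold lower number from compound 2 to compound 3 (0.01 log units; within the scatter), in no particular direction. Compound 3 is therefore expected to give an estimated 210000 nM in this assay, within a range of 100000 nM to 440000 nM.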

Compound 3, half-maximal cytotoxic concentration: < 197000 nM
Compound 3 gave a limit, no number; the forecaster's own chance of this, stated with the estimate: 15%; at least 1.0-fold (0.02 log units) between middle value and limit.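

In this assay compound 3 returned a limit and not a number: the limit of < 197000 nM in this assay, at which 1 of the 3 values shown sits. Nitro in place of hydroxy gives an at least 1.0-fold lower number from compound 2 to compound 3 (0.03 log units; that floor lies within the scatter), and nitro in place of fluoro gives an at least 1.0-fold lower number from compound 1 to compound 3 (0.03 log units; that floor lies within the scatter). The swap between fluoro and hydroxy could be read as leaving the two compounds level, but the steps to nitro are only floors, so this position is no longer known to be flat for every group placed on it, and a real step for nitro cannot be claimed either.

From the compounds shown here alone, how far the true value of compound 3 lies from those of compound 1 and compound 2 stays open, and with it whether this change moves the read-out beyond the scatter at all. Also open is what an amine, a carboxylic acid or a methoxy group would give at this same place on the ring, since the compounds shown cover only fluoro, hydroxy and nitro there.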